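This account rests on a few compounds, and the source may have more. Where it says the series, first, only, none or still open, it means among the compounds named here.

The piece follows the step from compound 2 to compound 4. In a functional assay on MCF7 cells (Homo sapiens) for inhibition, read by sulforhodamine B assay (a higher number here means a weaker inhibitor, a lower number a stronger inhibitor), compound 2 `O=C1C=C(Nc2ccccc2F)C(=O)c2c1nc1n2[C@H]2OC[C@@H](O)[C@H]2OC1` gives 3640 nM, the lowest of the two numbers shown. Compound 3 `COc1ccccc1NC1=CC(=O)c2c(nc3n2[C@H]2OC[C@@H](O)[C@H]2OC3)C1=O` gives 6580 nM in this assay, and its gap to compound 2 lies within the scatter. Compound 1 `O=C1C(NC2CCCC2)=CC(=O)c2c1nc1n2[C@H]2OC[C@@H](O)[C@H]2OC1` reaches only a limit in this assay, > 16000 nM. For the measured compounds named here, one measured step bears on the change at hand: an at least 2.4-fold lower number from compound 1 to compound 3 (0.38 log units; beyond the scatter), where the value of compound 1 is the limit of > 16000 nM in this assay, at which 1 of the 3 values shown sits. Compound 4 `CCCN(CCC)C1=CC(=O)c2nc3n(c2C1=O)[C@H]1OC[C@@H](O)[C@H]1OC3` differs from compound 2 in one place: dipropylamino in place of (2-fluorophenyl)amino on a double-bonded ring carbon. This runs in the opposite sense to the measured step, since there an aromatic ring entered on the amine nitrogen in place of cyclopentyl, whereas here the (2-fluorophenyl)amino group gives way to dipropylamino. A step of at least that size, toward a higher number, is therefore expected in this assay, and compound 4 may well end at a limit. Compound 4 is estimated at 12000 nM, between 4000 nM and 30000 nM, a step of a 3.3-fold higher number from compound 2 to compound 4 (0.52 log units; beyond the scatter).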

Compound 4, half-maximal inhibitory concentration: > 16000 nM
Compound 4: only a limit was reported; the forecaster's own chance of this, stated with the estimate: 40%; at least 1.3-fold (0.12 log units) between middle value and limit.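

In this assay, an at least 4.3-fold higher number from compound 2 to compound 4 (0.64 log units; beyond the scatter), the first step shown that starts from compound 2 and the first in which the amine nitrogen loses its hydrogen. The earlier step compared two groups that each keep that hydrogen, whereas this change removes the six-membered aromatic ring and the hydrogen-bond donor together. Compound 4 reaches only a limit, so its step is a bound and not a size, and dipropylamino now joins cyclopentyl, the other group without an aromatic ring, at the same limit: the limit of > 16000 nM in this assay, at which 2 of the 4 values shown sit.

The compounds shown do not separate the loss of the ring from the loss of the donor. Propylamino, which keeps the amine hydrogen without a ring, and N-methyl-2-fluoroanilino, which keeps the ring without that hydrogen, would each address one of the two.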